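The source may report more compounds than this note shows. Statements on the series, on what has been measured and on what is new or still open speak of the compounds shown alone.

Compound 1 `O=C(O)[C@H](CO)NC(=O)[C@H]1C[C@H](O)CN1`: > 12 h
Compound 2 `O=C(N[C@H](CO)C(=O)O)[C@@H]1C[C@H](O)CN1`: > 12 h

In an ADME assay (Mus musculus, strain C57BL/6) for metabolic stability, read by HPLC, with a stated time of 12 h (a lower number here means that the compound disappears faster, a higher number that the compound lasts longer), compound 2 gives > 12 h, which is a limit of the assay and not a number. Compound 1 gives > 12 h, which is also a limit. Among the compounds with values here, these two results share (the limit of > 12 h in this assay, at which 2 of the 2 values shown sit), so the only measured step is a step that the two limits leave unreadable from compound 1 to compound 2. That step still bears on the next compound, given (the fact that compounds 1 and 2 differ only in the configuration as drawn).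

Compound 3 `O=C(O)[C@H](CO)NC(=O)[C@@H]1C[C@H](O)CN1` arises from compound 2 through (the two compounds have the same atoms and bonds and differ only in configuration as drawn: 1 of 3 stereo elements differ; a stereocentre at a saturated chain carbon is drawn R in compound 2 and S in compound 3). Its chain stereocentre is therefore drawn as in compound 1, while its ring stereocentre is drawn as in compound 2. Neither parent, with > 12 h for compound 2, gives a readable number, so no size can be carried over, and no step beyond the scatter is expected. The expected change is a step that the limit leaves unreadable from compound 2 to compound 3. For compound 3, the estimated half-life is 15 h, expected within 9 h to 30 h.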

Compound 3, half-life: 1.22 h
Estimate against measurement, compound 3: 12-fold (1.09 log units) above; the measured number lies below the stated range.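

In this assay, configuration alone now gives a readable change, which compounds 1 and 2 could not show: each sits at a limit of the assay, and the step between them cannot be read. Redrawing only the saturated chain stereocentre gives an at least 9.8-fold lower number from compound 2 to compound 3 (0.99 log units; beyond the scatter), and redrawing only the saturated ring stereocentre gives an at least 9.8-fold lower number from compound 1 to compound 3 (0.99 log units; beyond the scatter). Compound 3 shares its ring drawing with compound 2 and its chain drawing with compound 1, so neither drawing alone goes with the shorter half-life, and the drop belongs to this particular combination of the two.

The compounds shown leave open why this combination lasts a shorter time and how far compound 1 and compound 2 lie past their limits. They also leave open whether a methyl ester in place of the carboxylic acid would keep the same gap.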